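Acyl-CoA desaturase 1 inhibitors: substitution on the amide aryl ring

This account rests on a few compounds, and the source may have more. Where it says the series, first, only, none or still open, it means among the compounds named here.

Measured so far:
compound 1 `Cc1ccc(C(=O)Nc2ncc(Cc3cccc(C(F)(F)F)c3)s2)cc1C` — 8220 nM
compound 2 `COc1cccc(C(=O)Nc2ncc(Cc3cccc(C(F)(F)F)c3)s2)c1` — 193 nM

Within the data shown here, in an assay on microsomes for inhibition of acyl-CoA desaturase 1 (Mus musculus), with a stated time of 60 min (on this read-out lower numbers stand for stronger inhibition and higher numbers for weaker inhibition), compound 2 stands lowest of the two numbers; its only neighbour is compound 1, reached by a 43-fold lower number from compound 1 to compound 2 (1.63 log units; beyond the scatter). Compound 3 `COc1cc(C(=O)Nc2ncc(Cc3cccc(C(F)(F)F)c3)s2)ccc1OCCO` differs from compound 2 by 2-hydroxyethoxy in place of hydrogen on an aromatic carbon. Among the measured compounds shown here, no measured step touches this position: the single recorded step swaps the whole aryl group on the carbonyl carbon, so it gives no direct guide. With nothing pointing either way, a change within the scatter is expected. Compound 3 is expected at 200 nM, with a range from 60 nM to 700 nM. The step this estimate implies is a 1.0-fold higher number from compound 2 to compound 3 (0.02 log units; within the scatter), expected to stay within the scatter.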

Compound 3, half-maximal inhibitory concentration: 3 nM
For compound 3 the middle estimate is 67-fold (1.82 log units) above the measured one; the measured number lies below the stated range.
By their numbers in this assay, from the lowest: compound 3; then compound 2; then compound 1.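

In this assay, 2-hydroxyethoxy in place of hydrogen on an aromatic carbon, ortho to a methoxy group and para to a large group, gives a 64-fold lower number from compound 2 to compound 3 (1.81 log units; beyond the scatter). This position, untouched by the earlier step, therefore accepts a chain and the read-out responds strongly to it. Nothing available accounts for the size of this step.

The compounds shown do not separate 2-hydroxyethoxy from a plain ethoxy, a longer chain, an amine or a carboxylic acid on this carbon. On these data alone, whether the gain depends on the methoxy group also stays open.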